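Ester Chain Extension in a Dinitrophenyl Glutathione Series

The source may hold more compounds than are shown below. What is called first, only, known or untested is meant among the compounds shown, and "the series" means these compounds.

Measured compounds:
compound 1, `CCOC(=O)CNC(=O)C(CSc1ccc([N+](=O)[O-])cc1[N+](=O)[O-])NC(=O)CCC(NC(=O)OCc1ccccc1)C(=O)O`, 1.82 in a physicochemical assay for lipophilicity; on this read-out lower numbers stand for lower lipophilicity and higher numbers for higher lipophilicity
compound 2, `CC(C)OC(=O)CNC(=O)C(CSc1ccc([N+](=O)[O-])cc1[N+](=O)[O-])NC(=O)CCC(NC(=O)OCc1ccccc1)C(=O)O`, 2.23 in this assay

Among the two measured compounds, compound 2 stands highest in this assay; the only other compound, compound 1, sits lower, the step being a number 0.41 log units higher from compound 1 to compound 2 (beyond the scatter). Compound 3, `CCCC(C)OC(=O)CNC(=O)C(CSc1ccc([N+](=O)[O-])cc1[N+](=O)[O-])NC(=O)CCC(NC(=O)OCc1ccccc1)C(=O)O`, differs from compound 2 by ethyl in place of hydrogen on a saturated chain carbon, two bonds along the chain from an oxygen next to a carbonyl group. Within the data shown here, the one step that bears on this is the one from compound 1 to compound 2, where a single carbon entered at a nearby place on the same ester chain and gave a modest rise beyond the scatter. With the ethyl group entering here, compound 3 is expected to lie higher than compound 2, the expected step being a number 0.87 log units higher from compound 2 to compound 3 (beyond the scatter). Compound 3 is therefore estimated at 3.1, within a range of 2.7 to 3.5.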

Compound 3, partition coefficient: 2.8
The estimate for compound 3 lay 0.30 log units above the measured number; the measured number falls inside the stated range.
By their numbers in this assay, from the lowest: compound 1; then compound 2; then compound 3.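

In this assay, ethyl in place of hydrogen on this saturated chain carbon extends the rise seen with the first added carbon, giving a number 0.57 log units higher from compound 2 to compound 3 (beyond the scatter). Propyl in place of hydrogen on the carbon bound to the ester oxygen gives a number 0.98 log units higher from compound 1 to compound 3 (beyond the scatter), so the numbers climb across all three compounds, with none going against that order. Nothing available explains the rise.

The compounds shown leave open whether a longer chain at this place would raise the number further, and what an amine or a carboxylic acid on the same chain would do.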